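The source may report more compounds than this note shows. Statements on the series, on what has been measured and on what is new or still open speak of the compounds shown alone.

In a toxicity assay on THP-1 cells (Homo sapiens) for inhibition (on this read-out higher numbers stand for lower toxicity in this test and lower numbers for higher toxicity in this test), compound 1 `COc1ccc(-c2cnc(NC(=O)c3ncc[nH]3)n2C)cc1` gives > 100000 nM, which is a limit of the assay and not a number. Compound 2 `COc1ccc(-c2cnc(NC(=O)c3ccccc3F)n2C)cc1` gives > 100000 nM, and this too is only a limit. The record so far therefore consists of the limit of > 100000 nM in this assay, at which 2 of the 2 values shown sit, and compound 2 has no exact value. Compound 3 `COc1ccc(-c2cnc(NC(=O)c3cccc(C)c3)n2C)cc1` keeps the shared core and places 3-methylphenyl in place of 2-fluorophenyl on a carbonyl carbon, a change counted as 3-methylphenyl in place of 2-fluorophenyl on a carbonyl carbon. Within the data shown here, the only measured step that bears on this change is a step that the two limits leave unreadable from compound 1 to compound 2, and it gives neither a size nor a direction to carry over. No movement beyond the scatter is therefore expected in this assay. The estimated step is a number no higher from compound 2 to compound 3 (the limit leaves the size open). Compound 3 is expected at 100000 nM, with an estimated range from 40000 nM to 150000 nM.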

Compound 3, half-maximal cytotoxic concentration: > 100000 nM
Compound 3: no number, only a limit (the forecaster's own chance of this, stated with the estimate: 85%); the middle value sits exactly at the limit.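

Compound 1, compound 2 and compound 3 all stand at a limit in this assay and not at a number, so no step among them can be read: the limit of > 100000 nM in this assay, at which 3 of the 3 values shown sit.

In this assay the compounds shown leave open how far each lies from that limit, and whether changing the group on the carbonyl carbon moves the read-out at all.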